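Swapping a crotonamide for an ethylurea on a diaryl ether

The source may report more compounds than this note shows. Statements on the series, on what has been measured and on what is new or still open speak of the compounds shown alone.

Measured so far:
Compound 1 `CCCC(=O)Nc1ccc(Oc2cccc(OC)c2)cc1` — 63 nM
Compound 2 `C/C=C/C(=O)Nc1ccc(Oc2cccc(OC)c2)cc1` — 98 nM

Both compounds share the same diaryl ether core and differ only in the chain on the carbonyl carbon. In an assay on isolated protein for binding affinity to melatonin receptor type 1A (Homo sapiens) (a higher number here means a weaker inhibitor, a lower number a stronger inhibitor), compound 1 gives 63 nM, and compound 2 gives 98 nM. The one step recorded, a 1.6-fold higher number from compound 1 to compound 2 (0.19 log units; within the scatter), is within the scatter, so on the numbers shown compound 2 has the higher of the two values but cannot be called weaker than compound 1 in any firm sense.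

Compound 3 `CCNC(=O)Nc1ccc(Oc2cccc(OC)c2)cc1` is not yet measured. It differs from compound 2 by ethylamino in place of prop-1-en-1-yl on a carbonyl carbon. This turns an amide into a urea, a change of kind rather than of chain length. Among the measured compounds shown here, no measured step touches such a change: the step from compound 1 to compound 2 only exchanged one three-carbon chain for another and barely moved the number. There is therefore no direct guide in the data. Given the absence of a comparable step, compound 3 is expected to sit at or somewhat above compound 2, with a step of about a 3.1-fold higher number from compound 2 to compound 3 (0.49 log units; beyond the scatter), and an estimated 300 nM, ranging from 80 nM to 1200 nM.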

Compound 3, inhibition constant: > 500 nM
Compound 3: no number, only a limit; the forecaster's own chance of this, stated with the estimate: 5%; middle value at least 1.6-fold (0.22 log units) from the limit.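

In this assay compound 3 gives > 500 nM, which is a limit of the assay and not a number. Putting ethylamino on the carbonyl carbon, which turns the amide into a urea, gives an at least 5.1-fold higher number from compound 2 to compound 3 (0.70 log units; beyond the scatter) and an at least 7.9-fold higher number from compound 1 to compound 3 (0.89 log units; beyond the scatter), so this position, where the exchange of propyl for prop-1-en-1-yl stayed within the scatter, does respond to what is attached there. Ethylamino and prop-1-en-1-yl carry the same count of heavy atoms, so that count does not separate them; what differs is a nitrogen in place of a carbon, together with the hydrogen-bond donor that enters with it.

As far as these compounds go, how much weaker compound 3 really is stays open, since the steps to it rest on a limit rather than on a number: the limit of > 500 nM in this assay, at which 1 of the 3 values shown sits. The compounds shown also cannot tell whether the urea link itself or its ethyl group accounts for the change, and a methylamino group, a longer propylamino chain or an ethoxy group on the same carbonyl carbon would be needed to separate those readings.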